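The source may hold more compounds than are shown below. What is called first, only, known or untested is meant among the compounds shown, and "the series" means these compounds.

Measured so far in a functional assay on HT-29 cells (Homo sapiens) for cytotoxicity, read by MTT assay, with a stated time of 72 h; on this read-out lower numbers stand for stronger inhibition and higher numbers for weaker inhibition:
- compound 1 `Cc1c(C(=O)Nc2ccc(Oc3ccnc4[nH]ccc34)c(F)c2)nnn1-c1ccccc1F`: 180 nM
- compound 2 `Cc1c(C(=O)Nc2ccc(Oc3ccnc4[nH]ccc34)cc2)nnn1-c1ccccc1F`: 360 nM

Compound 2 holds the higher of the two numbers, but its nearest neighbour is compound 1, and the step of a 2.0-fold higher number from compound 1 to compound 2 (0.30 log units; within the scatter) lies within the scatter, so the two cannot be ordered on these data. Compound 3 `Cc1c(C(=O)Nc2ccc(Oc3ccnc4[nH]ccc34)cc2)nnn1-c1ccc(F)c(F)c1` has not been measured. It differs from compound 2 by 3,4-difluorophenyl in place of 2-fluorophenyl on an aromatic nitrogen. Among the measured compounds shown here, the only measured step, from compound 1 to compound 2, concerns a change at a different place in the molecule, so it bears on the present change only in a general sense: it shows that altering a fluoro on an aromatic ring left the number within the scatter. For the measured compounds named here, no measured pair shows what a change on the ring attached to the aromatic nitrogen does. The expectation for compound 3 is therefore a step of no change at the digits printed from compound 2 to compound 3 (within the scatter) that stays within the scatter, with the direction unknown. Compound 3 is estimated at 360 nM, within a range from 120 nM to 1100 nM.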

Compound 3, half-maximal inhibitory concentration: 1070 nM
Estimate against measurement, compound 3: 3.0-fold (0.47 log units) below; the range from low to high includes it.
By their numbers in this assay, from the lowest: compounds 1 and 2 (each within the scatter of the next); then compound 3.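

In this assay, replacing 2-fluorophenyl with 3,4-difluorophenyl on the aromatic nitrogen of the five-membered ring gives a 3.0-fold higher number from compound 2 to compound 3 (0.47 log units; beyond the scatter), a modest step towards weaker inhibition and the first in this series to lie beyond the scatter. Among the compounds shown here, this shows that the number responds to the aryl group at this position, which the earlier pair could not show, since its single step concerned a different place in the molecule and stayed within the scatter. The change adds a fluorine and also alters the substitution pattern of the ring, so the step cannot be assigned to either alteration alone, and nothing available here speaks to its cause.

The compounds shown leave open what an unsubstituted phenyl, a 4-fluorophenyl or a 4-methoxyphenyl would give on this nitrogen, and so whether the 2-fluorophenyl of compound 2 is itself favourable or the 3,4-difluorophenyl of compound 3 is unfavourable. They also leave open whether the fluoro that separates compound 1 from compound 2 would have any bearing on a compound carrying 3,4-difluorophenyl.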